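This account rests on a few compounds, and the source may have more. Where it says the series, first, only, none or still open, it means among the compounds named here.

Compound 1, `COc1cc(C)cc(-c2c(-c3ccnc(-c4ccc(C(C)=O)cc4)c3)cnn2CC#N)c1`: in a functional assay on OVCAR-8 cells (Homo sapiens) for inhibition, read by sulforhodamine B assay, with a stated time of 48 h (a lower number here means a stronger inhibitor of growth, a higher number a weaker inhibitor of growth), compound 1 gives only a limit, > 100000 nM.
Compound 2, `Cc1cc(O)cc(-c2nn(CC#N)cc2-c2ccnc(-c3ccc(Oc4ccccc4)cc3)c2)c1`: in this assay compound 2 gives 5540 nM.

Going by the values given here, compound 2 thus holds the only actual number in this assay; the other entry, that of compound 1, is a limit, as the limit of > 100000 nM in this assay, at which 1 of the 2 values shown sits, records. Among the compounds with values here, no pair of measured compounds differs in just one place, so this set contains no measured step that would show how any single change moves the concentration for total growth inhibition.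

Compound 3, `Cc1cc(O)cc(-c2nn(CC#N)cc2-c2ccnc(-c3ccc(N(C)C)cc3)c2)c1`, is the unmeasured compound. It differs from compound 2 in a single place: dimethylamino in place of phenoxy on an aromatic carbon. The rest of the molecule is unchanged from compound 2.

Within the data shown here, with no measured step to lean on, the direction of the change from compound 2 to compound 3 is open. Compound 3 is expected to land near compound 2, with a step of a 1.4-fold higher number from compound 2 to compound 3 (0.16 log units; within the scatter) that need not pass beyond the usual scatter. In this assay compound 3 is therefore estimated at about 8000 nM, expected to fall somewhere between 2000 nM and 40000 nM.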

Compound 3, concentration for total growth inhibition: 69400 nM
The estimate for compound 3 lay 8.7-fold (0.94 log units) below the measured number, outside the stated range (above it).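

Going by these compounds alone, the swap of phenoxy for dimethylamino gives the first measured step in this assay, a 13-fold higher number from compound 2 to compound 3 (1.10 log units; beyond the scatter), which shows that the group on this aromatic carbon, para to a large group, can move the concentration for total growth inhibition well beyond the usual scatter. With the rest of the molecule unchanged, the step goes with the loss of a six-membered aromatic ring of carbon only and a fall from 7 heavy atoms to 3, while the counts of hydrogen-bond donors and acceptors stay the same, so those counts do not separate the two groups. Nothing measured here bears on why this change has such an effect.

This single pair cannot tell whether the step follows the loss of the ring, the exchange of oxygen for nitrogen at the point of attachment, or both together. An anilino group, which would keep the ring with a nitrogen link, or a morpholine, which would bring a saturated ring, could help to separate these readings, but the compounds shown do not include either group at this position.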